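The source may hold more compounds than are shown below. What is called first, only, known or untested is meant among the compounds shown, and "the series" means these compounds.

Series in a functional assay on ASPC1 cells (Homo sapiens) for antiproliferative activity, read by sulforhodamine B assay, with a stated time of 48 h; a higher number here means a weaker inhibitor, a lower number a stronger inhibitor:
- compound 1 `O=C(CCCCCCN1C(=O)/C(=N\O)c2cc(Br)ccc21)NO`: 80 nM
- compound 2 `O=C(CCCCCCN1C(=O)/C(=N\O)c2cc([N+](=O)[O-])ccc21)NO`: 4680 nM
- compound 3 `CO/N=C1/C(=O)N(CCCCCCC(=O)NO)c2ccc(F)cc21`: 970 nM

Compound 3, at 970 nM, holds the second highest of the three numbers, under compound 2 and over compound 1, with both gaps beyond the scatter. Compound 4 `CO/N=C1/C(=O)N(CCCCCCC(=O)NO)c2ccc(C)cc21` carries methyl in place of fluoro on an aromatic carbon.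

Going by the values given here, only one measured step bears on this change: a 59-fold higher number from compound 1 to compound 2 (1.77 log units; beyond the scatter), a large step with nitro in place of bromo on an aromatic carbon. It shows that a single swap of this kind can move the number a long way in this series. However, it involves neither fluoro nor methyl, and both of its compounds also differ from compound 3 elsewhere. No firm direction follows from it, so only a small step is expected in this assay, none beyond the scatter. The expected step is a 1.3-fold lower number from compound 3 to compound 4 (0.11 log units; within the scatter). For compound 4 the estimated value is 750 nM, with an expected range of 250 nM to 2500 nM.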

Compound 4, half-maximal inhibitory concentration: 5480 nM
Estimate against measurement, compound 4: 7.3-fold (0.86 log units) below; the measured number lies above the stated range.
By their numbers in this assay, from the lowest: compound 1; then compound 3; then compounds 2 and 4 (each within the scatter of the next).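

In this assay, methyl in place of fluoro on this aromatic carbon gives a 5.6-fold higher number from compound 3 to compound 4 (0.75 log units; beyond the scatter), so even an exchange of one heavy atom for one heavy atom, with no change in the hydrogen-bond donor or acceptor counts, moves the number beyond the scatter. Alongside a 59-fold higher number from compound 1 to compound 2 (1.77 log units; beyond the scatter), this shows that the same aromatic carbon matters on the core shared by compounds 3 and 4 as well as on the core shared by compounds 1 and 2, although the two steps involve different groups and cannot be ranked as one trend. Nothing available accounts for the loss seen with methyl. As far as these compounds go, it remains open whether methyl in place of fluoro would move the number the same way on the core of compound 1. From the compounds shown here alone, how chloro or an amine on this carbon would read on either core is also open.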